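Propyl Amide in Place of the Aryl Hydrazide

A few compounds are considered here, and "the series" means these few. Any claim that something is new, unique, unknown or untested is made for them only; others in the source may bear on it.

compound 1 `NNC(=O)c1c(NC(=O)NS(=O)(=O)c2ccccc2)sc2c1CCCCC2` in a functional assay on MCF7 cells (Homo sapiens) for inhibition, with a stated time of 48 h; on this read-out lower numbers stand for stronger inhibition of growth and higher numbers for weaker inhibition of growth: 4200 nM
compound 2 `CN1CCN(C(=O)c2c(NC(=O)NS(=O)(=O)c3ccccc3)sc3c2CCCCC3)CC1` in this assay: > 100000 nM, a limit of the assay and not a number
compound 3 `O=C(Nc1sc2c(c1C(=O)NNc1ccc(Cl)cc1)CCCCC2)NS(=O)(=O)c1ccccc1` in this assay: 8300 nM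

Compound 3 holds the highest of the two numbers; its nearest neighbour is compound 1, and a 2.0-fold higher number from compound 1 to compound 3 (0.30 log units; within the scatter) lies within the scatter. Compound 2 sits at the limit of > 100000 nM in this assay, at which 1 of the 3 values shown sits. Compound 4 `CCCNC(=O)c1c(NC(=O)NS(=O)(=O)c2ccccc2)sc2c1CCCCC2` differs from compound 3 by propyl in place of (4-chlorophenyl)amino on an amide-type nitrogen. The steps of an at least 23-fold higher number from compound 1 to compound 2 (1.37 log units; beyond the scatter) and an at least 12-fold lower number from compound 2 to compound 3 (1.08 log units; beyond the scatter) show that exchanging the hydrazide-type groups on the carbonyl carbon for 4-methylpiperazin-1-yl cost a great deal, whereas 4-chlorophenyl on the amine nitrogen changed little. Propylamino removes one nitrogen but, unlike the piperazine, is not cyclic, so a moderate weakening is expected, a 2.2-fold higher number from compound 3 to compound 4 (0.34 log units; beyond the scatter). Compound 4 is estimated at 18000 nM, between 4000 nM and 90000 nM.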

Compound 4, concentration for 50% growth inhibition: > 100000 nM
Compound 4: only a limit was reported; the forecaster's own chance of this, stated with the estimate: 25%; middle value at least 5.5-fold (0.74 log units) away from the limit.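

In this assay compound 4 gives > 100000 nM, a limit of the assay and not a number. Propyl on the amide-type nitrogen therefore does not keep the growth inhibition of the hydrazide-type groups, with an at least 12-fold higher number from compound 3 to compound 4 (1.08 log units; beyond the scatter) and an at least 23-fold higher number from compound 1 to compound 4 (1.37 log units; beyond the scatter), so the large loss seen with the 4-methylpiperazin-1-yl group of compound 2 also occurs with a group that has no ring. The step between compound 2 and compound 4 cannot be read, as both stand at a limit: the limit of > 100000 nM in this assay, at which 2 of the 4 values shown sit.

From the compounds shown here alone, it remains open whether the second nitrogen of the hydrazide is what matters, or whether a hydroxyl or a methoxy group on the amide-type nitrogen would serve as well.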